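The source may report more compounds than this note shows. Statements on the series, on what has been measured and on what is new or still open speak of the compounds shown alone.

Of the compounds shown here, three on a shared core have been measured so far in a functional assay on HeLa cells (Homo sapiens) for antiproliferative activity, with a stated time of 48 h (a higher number here means a weaker inhibitor, a lower number a stronger inhibitor), on this read-out. Compound 1 `C=C(Br)C(=O)Nc1ccc(C(=O)/C=C/c2cccc(OC)c2)cc1` stands at 500 nM and compound 2 `C=C(Br)C(=O)Nc1ccc(C(=O)/C=C/c2ccc(OC)c(OC)c2)cc1` at 770 nM on these numbers. Compound 3 `C=C(Br)C(=O)Nc1ccc(C(=O)/C=C/c2cc(OC)cc(OC)c2)cc1` has the highest number of the three at 1700 nM and is thus the weakest inhibitor among them. Compound 4 `C=C(Br)C(=O)Nc1ccc(C(=O)/C=C/c2cc(OC)c(OC)c(OC)c2)cc1` differs from compound 3 by a single change, methoxy in place of hydrogen on an aromatic carbon and nothing else. Two measured steps make the same kind of replacement. The closer match, with its added methoxy also para to a large group, is a 1.5-fold higher number from compound 1 to compound 2 (0.19 log units; within the scatter) and the other, at a different place, is a 3.4-fold higher number from compound 1 to compound 3 (0.53 log units; beyond the scatter) and so keeps a rise possible. The closer step therefore carries more weight, and no step beyond the scatter is expected in this assay for this change. The expected result is a 1.2-fold lower number from compound 3 to compound 4 (0.08 log units; within the scatter) as a small move of uncertain direction. Compound 4 is estimated at 1400 nM with an expected range from 450 nM to 3200 nM as its likely span.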

Compound 4, half-maximal inhibitory concentration: 420 nM
The estimate for compound 4 lay 3.3-fold (0.52 log units) above the measured number; measured number outside the range, below it.
By their numbers in this assay, from the lowest: compounds 4, 1 and 2 (each within the scatter of the next); then compound 3.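

In this assay, among these compounds, a methoxy ortho to two methoxy groups and para to a large group gives a 4.0-fold lower number from compound 3 to compound 4 (0.61 log units; beyond the scatter), the first step of this change to a lower number beyond the scatter. The other single replacement leading to the same product gives a 1.8-fold lower number from compound 2 to compound 4 (0.26 log units; within the scatter), so that step alone does not separate the two compounds. The outcome of this change therefore varies with the methoxy groups already on the ring, and its size and direction do not carry over from one core to the next: the same change on two cores in this assay, a 1.5-fold higher number (0.19 log units; within the scatter) from compound 1 to compound 2 and a 4.0-fold lower number (0.61 log units; beyond the scatter) from compound 3 to compound 4, 6.2-fold (0.79 log units) apart, beyond the scatter of two such steps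

As far as these compounds go, whether the lower number needs a methoxy at this place, or would also follow with a hydroxyl, an ethoxy group or an amine there, remains open. The compounds shown also leave open whether the bromoacrylamide part contributes to the pattern seen in this assay.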